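The compounds below may be only part of what the source reports. "The series", "measured", "known", "first", "only" and "open" are said of these compounds alone.

Series notes. The shared core carries a 4-chlorophenyl group, a nitrile or carboxamide, and a sulfamoylphenylamino substituent; the compounds differ at the amine nitrogen on the ring. Compound 1 `CC(=O)NC1=C(C#N)C(c2ccc(Cl)cc2)c2sc(Nc3ccc(S(N)(=O)=O)cc3)nc2O1` bears an acetyl there and in a functional assay on MCF7 cells (Homo sapiens) for antiproliferative activity, read by sulforhodamine B assay, with a stated time of 48 h (a higher number here means a weaker inhibitor, a lower number a stronger inhibitor), compound 1 gives 41900 nM. Compound 2 `NC(=O)C1=C(N)Oc2nc(Nc3ccc(S(N)(=O)=O)cc3)sc2C1c1ccc(Cl)cc1`, with a free amino group and a carboxamide in place of the nitrile, gives 41800 nM, and compound 3 `N#CC1=C(NS(=O)(=O)c2ccccc2)Oc2nc(Nc3ccc(S(N)(=O)=O)cc3)sc2C1c1ccc(Cl)cc1`, with a phenylsulfonyl on the amine nitrogen, gives 47500 nM. Among the measured compounds shown here, all three numbers sit within the scatter of one another; compound 1 is neither set apart from compound 2 nor from compound 3, and no compound of the three can be called the strongest or weakest.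

For the measured compounds named here, the single step among measured compounds that bears on the next one is a 1.1-fold higher number from compound 1 to compound 3 (0.05 log units; within the scatter), a change that did not move the number beyond the scatter.

Compound 4 `Cc1ccc(S(=O)(=O)NC2=C(C#N)C(c3ccc(Cl)cc3)c3sc(Nc4ccc(S(N)(=O)=O)cc4)nc3O2)cc1` is not yet measured. Relative to compound 1 the change is (4-methylphenyl)sulfonyl in place of acetyl on an amine nitrogen. Going by the values given here, the closest precedent is the step from compound 1 to compound 3, where the acetyl-to-sulfonyl exchange was essentially flat; the added methyl on the aromatic ring has no measured counterpart here. On that basis, no step beyond the scatter is expected in this assay, in either direction, so compound 4 is estimated at 46000 nM with a range of 24000 nM to 90000 nM, a step of a 1.1-fold higher number from compound 1 to compound 4 (0.04 log units; within the scatter) expected from compound 1.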

Compound 4, half-maximal inhibitory concentration: 71700 nM
The estimate for compound 4 lay 1.6-fold (0.19 log units) below the measured number; the measured number falls inside the stated range.
By their numbers in this assay, from the lowest: compounds 2, 1, 3 and 4 (each within the scatter of the next).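

In this assay the exchange of acetyl for (4-methylphenyl)sulfonyl on the amine nitrogen gives a 1.7-fold higher number from compound 1 to compound 4 (0.23 log units; within the scatter) and stays within the scatter, so this position now has two sulfonyl-bearing examples, compound 3 and compound 4, neither of which is set apart from the acetyl of compound 1. Among the compounds shown here, the methyl in place of hydrogen on an aromatic carbon of the phenylsulfonyl group can also be read alone, as a 1.5-fold higher number from compound 3 to compound 4 (0.18 log units; within the scatter) and likewise within the scatter, giving the series its first measured substitution on that ring and no step that can be told from repeat-measurement noise. No measurement available here gives a reason for these steps or for the flat picture at this nitrogen.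

Still open, from the compounds shown here alone, is whether any group on this nitrogen can shift the number beyond the scatter, for instance a small methylsulfonyl, a benzoyl or a longer acyl chain. Also open, going by these compounds, is how a methoxy group, a chlorine or a carboxylic acid in place of the methyl on the aromatic ring would read, and whether the sulfonyl groups would behave the same alongside the carboxamide of compound 2.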